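Aryl series on the shared core: cyano for phenyl

A few compounds are considered here, and "the series" means these few. Any claim that something is new, unique, unknown or untested is made for them only; others in the source may bear on it.

Compounds measured in a functional assay on Raji cells (Homo sapiens) for cytotoxicity, read by CCK-8 assay, with a stated time of 24 h (a higher number here means a weaker inhibitor, a lower number a stronger inhibitor), so far:
compound 1 `C=CC(=O)N1C(=O)CC(c2ccc([N+](=O)[O-])cc2)Sc2ccccc21` gives 34800 nM
compound 2 `C=CC(=O)N1C(=O)CC(c2ccc(-c3ccccc3)cc2)Sc2ccccc21` gives 56300 nM
compound 3 `C=CC(=O)N1C(=O)CC(c2ccccc2C(F)(F)F)Sc2ccccc21` gives 50300 nM

Compound 2 carries the highest number of the three in this assay, yet its gap to compound 3 and to compound 1 is in each case within the scatter, so the three stand together without any order between them. For the measured compounds named here, the only single-point step among them, a 1.6-fold higher number from compound 1 to compound 2 (0.21 log units; within the scatter), is likewise within the scatter.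

Compound 4 `C=CC(=O)N1C(=O)CC(c2ccc(C#N)cc2)Sc2ccccc21` is not yet measured. It differs from compound 2 by cyano in place of phenyl on an aromatic carbon.

Going by the values given here, no measured step is an exact parallel, since the cyano group appears nowhere among compounds 1 to 3. The nearest guide is the step from compound 1 to compound 2, in which a phenyl replaced a nitro at the same place and left the number within the scatter. The expectation is therefore no step beyond the scatter in this assay; the estimate for compound 4 is 42000 nM, with the range 15000 nM to 110000 nM, which means an expected step of a 1.3-fold lower number from compound 2 to compound 4 (0.13 log units; within the scatter), leaning slightly toward the value of compound 1, because compound 1 gives 34800 nM with a small group at the same place.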

Compound 4, half-maximal inhibitory concentration: 84500 nM
Estimate against measurement, compound 4: 2.0-fold (0.30 log units) below; the measured number falls inside the stated range.
By their numbers in this assay, from the lowest: compounds 1, 3, 2 and 4 (each within the scatter of the next, the first and the last beyond it).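

In this assay the exchange of phenyl for cyano on an aromatic carbon, para to a large group, gives a 1.5-fold higher number from compound 2 to compound 4 (0.18 log units; within the scatter), so at this place the loss of the six-membered aromatic ring does not move the number beyond the scatter. The exchange of nitro for cyano at the same place gives a 2.4-fold higher number from compound 1 to compound 4 (0.39 log units; beyond the scatter), a modest step and the first in this series to lie beyond the scatter, so two groups without a ring of their own need not read alike here. Nothing measured on these compounds bears on the origin of that step.

Going by these compounds, whether an amine, a carboxylic acid or a longer chain at this place would move the number beyond the scatter from compound 2 stays open. Also open, on these data alone, is whether the exchange of nitro for cyano would give a similar step on another core.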